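A Hydroxyethyl Piperidine Amide Replaces an Ethyl Piperidine

A few compounds are considered here, and "the series" means these few. Any claim that something is new, unique, unknown or untested is made for them only; others in the source may bear on it.

Three compounds have been measured in an assay on HEK293 cells for displacement of a labelled ligand from NPC1-like intracellular cholesterol transporter 1 (Homo sapiens); a higher number here means a weaker inhibitor, a lower number a stronger inhibitor:

compound 1, `CC(C)(C)OC(=O)NCC1CCCN(C(=O)CN2CN(c3ccccc3)C3(CCN(C(=O)c4ccc(C5CCCCC5)cc4)CC3)C2=O)C1`: 3800 nM
compound 2, `COC(=O)CCCNC(=O)CN1CN(c2ccccc2)C2(CCN(C(=O)c3ccc(C4CCCCC4)cc3)CC2)C1=O`: 2500 nM
compound 3, `CCC1CCCN(C(=O)CN2CN(c3ccccc3)C3(CCN(C(=O)c4ccc(C(C)(C)C)cc4)CC3)C2=O)C1`: 3900 nM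

Compound 3 carries the highest of the three numbers, but its nearest neighbour compound 1 and its furthest neighbour compound 2 both lie within the usual scatter of it, so the three values show no separation that can be read as a difference in binding. Among the measured compounds shown here, no step between two measured compounds that differ in a single place is available.

Compound 4, `CC(C)(C)c1ccc(C(=O)N2CCC3(CC2)C(=O)N(CC(=O)N2CCC(CCO)CC2)CN3c2ccccc2)cc1`, is the next compound to be measured in this assay. It differs from compound 3 in one place: 4-(2-hydroxyethyl)piperidin-1-yl in place of 3-ethylpiperidin-1-yl on a carbonyl carbon.

The shared core and the amide on the other side are unchanged. Compound 1 and compound 2 carry other groups on this same carbonyl carbon, and compound 1 gives 3800 nM while compound 2 gives 2500 nM, both within the scatter of compound 3. On that basis the step from compound 3 to compound 4 is expected to stay within the scatter, a 1.1-fold lower number from compound 3 to compound 4 (0.05 log units; within the scatter), with no clear direction. Compound 4 is therefore estimated at 3500 nM, with a range from 1500 nM to 8000 nM.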

Compound 4, half-maximal inhibitory concentration: 2600 nM
Compound 4: the middle estimate sits 1.3-fold (0.13 log units) above what was measured; measured number inside the range.
By their numbers in this assay, from the lowest: compounds 2, 4, 1 and 3 (each within the scatter of the next).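

In this assay the exchange on this carbonyl carbon can now be read as a step in one place, and it gives a 1.5-fold lower number from compound 3 to compound 4 (0.18 log units; within the scatter) and so shows no difference that can be read as one in binding. The swap of 3-ethylpiperidin-1-yl for 4-(2-hydroxyethyl)piperidin-1-yl brings in one oxygen, one hydrogen-bond donor and one hydrogen-bond acceptor, and at this position that whole exchange leaves the number within the scatter. No supporting measurement bears on this result.

Because the two groups differ both in the chain and in where it stands on the ring, the compounds shown leave open what each of these contributes on its own, a question that 4-ethylpiperidin-1-yl or 3-(2-hydroxyethyl)piperidin-1-yl on the same carbonyl carbon could address. They also leave open whether a longer chain, an amine or a carboxylic acid in place of the terminal hydroxyl would give a value separated from the scatter.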